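The source may hold more compounds than are shown below. What is called first, only, known or untested is meant among the compounds shown, and "the series" means these compounds.

Measured so far:
- compound 1 `Cc1cccc2c1CC/C2=C\C(=O)NC1CC1` — 15%
- compound 2 `CNC(=O)/C=C1\CCc2ccc(Cl)cc21` — 0%
- compound 3 `NC(=O)/C=C1\CCc2cc(F)cc(F)c21` — 54%

Of the compounds shown here, three built on the same core have been tested in a functional assay on the whole organism with Rattus norvegicus as the target, at a dose of 20 mg/kg by the oral route; on this read-out lower numbers stand for less inhibition and higher numbers for more inhibition at the one dose given (going by the name of the read-out). Compound 1 gives 15%, the second highest of the three numbers. Its nearest neighbour is compound 2, which gives 0%, a lower number with a gap that lies beyond the usual scatter. The furthest is compound 3, which gives 54%, the highest number of the set and well beyond the scatter above compound 1.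

The next step leads from compound 1 to compound 4 `Cc1cccc2c1CC/C2=C\C(N)=O`. The change is hydrogen in place of cyclopropyl on an amide-type nitrogen. Going by the values given here, no pair of measured compounds isolates this change on its own: compound 3 is the only one whose amide-type nitrogen carries no substituent, yet compound 3 differs from compound 1 in its ring substituents as well, so its high value cannot be credited to the nitrogen alone. Still, the only unsubstituted amide-type nitrogen in the set sits on the compound with the highest number, compound 3, so a step upward in this assay of moderate size is expected, with the possibility that it stays within the scatter. Compound 4 is therefore expected to give 30%, with a range from 10% to 55%. This estimate means a step of a number 15 percentage points higher from compound 1 to compound 4 (beyond the scatter).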

Compound 4, a percentage reported as inhibition, in the whole organism at one dose (the size of the read-out at that dose, not a potency): 15%
Compound 4: the middle estimate sits 15 percentage points above what was measured; the measured number falls inside the stated range.
By their numbers in this assay, from the lowest: compound 2; then compounds 1 and 4 (each within the scatter of the next); then compound 3.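

In this assay, going by these compounds alone, hydrogen in place of cyclopropyl on the amide-type nitrogen gives no change at the digits printed from compound 1 to compound 4 (within the scatter), the first reading of this change on its own, since no earlier pair of compounds isolated it. On the core of compound 1, the cyclopropyl group can therefore be taken off this nitrogen without a step that stands out from the scatter, and an amide-type nitrogen without a substituent does not by itself raise the read-out on this core. Nothing in the data given here accounts for the two groups reading alike.

The compounds shown leave open whether a longer chain such as n-butyl, or a chain ending in an amine or a carboxylic acid, would read alike on this nitrogen of the core of compound 1. They also leave open whether hydrogen and cyclopropyl would read alike on a core carrying other ring substituents, such as the fluorines of compound 3.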